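A few compounds are considered here, and "the series" means these few. Any claim that something is new, unique, unknown or untested is made for them only; others in the source may bear on it.

Measured compounds:
- compound 1, `Clc1ccc(/C=N/Nc2nc3ccccc3nc2Cc2ccccc2)cc1`, in an assay on isolated protein for inhibition of Amine oxidase [flavin-containing] A (Homo sapiens), read by spectrophotometry (on this read-out higher numbers stand for weaker inhibition and lower numbers for stronger inhibition), compound 1 gives 76 nM
- compound 2, `Clc1ccccc1/C=N/Nc1nc2ccccc2nc1Cc1ccccc1`, compound 2 gives 5.8 nM
- compound 3, `Oc1ccc(/C=N/Nc2nc3ccccc3nc2Cc2ccccc2)cc1`, compound 3 gives 3.4 nM

Compound 3 has the lowest number of the three, but the step of a 1.7-fold lower number from compound 2 to compound 3 (0.23 log units; within the scatter) lies within the scatter, so these two cannot be ordered; only compound 1 stands clearly apart, as a 22-fold lower number from compound 1 to compound 3 (1.35 log units; beyond the scatter) shows.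

Compound 4, `C/C(=N\Nc1nc2ccccc2nc1Cc1ccccc1)c1ccccn1`, differs from compound 3 in one place: a group of 9 heavy atoms (7 carbon, 2 nitrogen; one six-membered aromatic ring with 1 hetero atom) in place of a group of 9 heavy atoms (7 carbon, 1 nitrogen, 1 oxygen; one six-membered aromatic ring of carbon only), on a nitrogen on an aromatic ring. Among the compounds with values here, two measured steps touch the same region. The step of a 22-fold lower number from compound 1 to compound 3 (1.35 log units; beyond the scatter) was large, and a 13-fold lower number from compound 1 to compound 2 (1.12 log units; beyond the scatter) was large too, so changes on this side of the shared core have moved the number well beyond the scatter. Neither step, however, involves a ring with a hetero atom or a methyl on the carbon with a double bond to nitrogen, so the direction for compound 4 cannot be read from them directly. Since the hydroxy that entered in a 22-fold lower number from compound 1 to compound 3 (1.35 log units; beyond the scatter) is lost here, compound 4 is expected to give a somewhat higher number, an 8.8-fold higher number from compound 3 to compound 4 (0.95 log units; beyond the scatter), with a wide range. Compound 4 is therefore estimated at 30 nM, between 5 nM and 200 nM.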

Compound 4, half-maximal inhibitory concentration: 91 nM
Compound 4: middle estimate off by 3.0-fold (0.48 log units), on the low side; low and high end bracket the measured number.
By their numbers in this assay, from the lowest: compounds 3 and 2 (each within the scatter of the next); then compounds 1 and 4 (each within the scatter of the next).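

In this assay, the group with a six-membered aromatic ring with 1 hetero atom, on a nitrogen on an aromatic ring, gives a 27-fold higher number from compound 3 to compound 4 (1.43 log units; beyond the scatter) and a 16-fold higher number from compound 2 to compound 4 (1.20 log units; beyond the scatter), so a large step at this position also appears with a group that has no chlorine, and compound 2 shows that having no hydroxy does not alone go with such a number. Against the 4-chlorophenyl of compound 1 the same exchange gives a 1.2-fold higher number from compound 1 to compound 4 (0.08 log units; within the scatter), so the chlorine's place on the ring separates compound 1 and compound 2 far more than this exchange separates compound 1 and compound 4. No available evidence accounts for these steps.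

The compounds shown leave open how much of the step belongs to the methyl and how much to the ring hetero atom, since the two enter together. They also leave open whether a methoxy or an amine in place of the hydroxy would keep the number of compound 3.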